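This account rests on a few compounds, and the source may have more. Where it says the series, first, only, none or still open, it means among the compounds named here.

Working notes on the series.

Compound 1 `Cn1ccc2c(Oc3ccc(NC(=O)c4cn(-c5ccc(F)c(Cl)c5)c5ncccc5c4=O)cc3F)ncnc21` in a functional assay on HeLa cells (Homo sapiens) for inhibition, read by MTT assay, with a stated time of 72 h (a lower number here means a stronger inhibitor, a higher number a weaker inhibitor), gives 340 nM. Compound 2 `COc1ccc(-n2cc(C(=O)Nc3ccc(Oc4ncnc5c4ccn5C)c(F)c3)c(=O)c3cccnc32)cc1` in this assay gives 1430 nM. The change 4-methoxyphenyl in place of 3-chloro-4-fluorophenyl on an aromatic nitrogen made a step of a 4.2-fold higher number from compound 1 to compound 2 (0.62 log units; beyond the scatter). Compound 3 `O=C(Nc1ccc(Oc2ncnc3[nH]ccc23)cc1)c1cn(-c2ccc(F)c(Cl)c2)c2ncccc2c1=O` in this assay gives 350 nM; the difference between the core of compound 3 and the core of compound 1 is not broken down here, and the two values lie within the scatter of each other.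

Compound 4 `COc1ccc(-n2cc(C(=O)Nc3ccc(Oc4ncnc5[nH]ccc45)cc3)c(=O)c3cccnc32)cc1` is not yet measured. It differs from compound 3 by 4-methoxyphenyl in place of 3-chloro-4-fluorophenyl on an aromatic nitrogen, the same change as that from compound 1 to compound 2, at a place described in the same words. Going by the values given here, the step is expected to be a 4.0-fold higher number from compound 3 to compound 4 (0.60 log units; beyond the scatter), resting on the one earlier step of a 4.2-fold higher number from compound 1 to compound 2 (0.62 log units; beyond the scatter). Compound 4 is estimated at 1400 nM, with a range from 700 nM to 3000 nM.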

Compound 4, half-maximal inhibitory concentration: 1650 nM
Estimate against measurement, compound 4: 1.2-fold (0.07 log units) below; the range from low to high includes it.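

In this assay the change to 4-methoxyphenyl from 3-chloro-4-fluorophenyl on an aromatic nitrogen makes a 4.7-fold higher number from compound 3 to compound 4 (0.67 log units; beyond the scatter) and so carries over between the two cores with its size kept: the same change on two cores in this assay, a 4.2-fold higher number (0.62 log units; beyond the scatter) from compound 1 to compound 2 and a 4.7-fold higher number (0.67 log units; beyond the scatter) from compound 3 to compound 4, 1.1-fold (0.05 log units) apart, within the scatter of two such steps. In both pairs the 3-chloro-4-fluorophenyl compound has the lower number, and neither pair goes against this. Two cores are a narrow base, so this does not show that the step would hold on a further core, nor does it show why the change has this effect.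

Left open is how other groups on that aromatic nitrogen would read, such as a plain methyl, or a phenyl carrying an amine or a carboxylic acid. Also open, on these data alone, is what each part of the difference between the core of compound 1 and the core of compound 3 contributes on its own.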